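Replacing a Formyl Group with a Benzoylethenyl Chain

This account rests on a few compounds, and the source may have more. Where it says the series, first, only, none or still open, it means among the compounds named here.

Compound 1 `CCC(C)c1cc(/C=C/C(=O)c2ccccc2)cc2cc(C(=O)OC)c(=O)oc12`: 13400 nM
Compound 2 `CCOC(=O)c1cc2cc(/C=C/C(=O)c3ccc(C)cc3)cc(C(C)CC)c2oc1=O`: 18000 nM
Compound 3 `CCOC(=O)c1cc2cc(C=O)cc(C(C)CC)c2oc1=O`: 132000 nM

All three were tested in a functional assay on KB cells (Homo sapiens) for cytotoxicity, read by sulforhodamine B assay, with a stated time of 48 h; a lower number here means a stronger inhibitor, a higher number a weaker inhibitor. Compound 3 stands highest of the three numbers, and thus is the weakest inhibitor here; compound 2 is its nearest neighbour and compound 1 lies furthest away, both gaps beyond the scatter.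

Compound 4 `CCOC(=O)c1cc2cc(/C=C/C(=O)c3ccccc3)cc(C(C)CC)c2oc1=O` differs from compound 3 in one place: 2-benzoylethenyl in place of formyl on an aromatic carbon. Among the measured compounds shown here, no step of this kind has been measured directly, so its size is a guess. Still, compound 1 and compound 2 both carry this same 2-benzoylethenyl group and both sit far below compound 3, which points to a large step toward stronger inhibition. The step from compound 3 to compound 4 is estimated at an 8.8-fold lower number from compound 3 to compound 4 (0.94 log units; beyond the scatter). Compound 4 is expected to give 15000 nM in this assay, within a range from 7000 nM to 32000 nM.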

Compound 4, half-maximal inhibitory concentration: 10500 nM
For compound 4 the middle estimate is 1.4-fold (0.15 log units) above the measured one; the range from low to high includes it.
By their numbers in this assay, from the lowest: compounds 4, 1 and 2 (each within the scatter of the next); then compound 3.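

In this assay the size of this change at this position can now be read directly, with only the formyl group exchanged for 2-benzoylethenyl: a 13-fold lower number from compound 3 to compound 4 (1.10 log units; beyond the scatter). Hydrogen in place of methyl on the ring of the benzoyl group gives a 1.7-fold lower number from compound 2 to compound 4 (0.23 log units; within the scatter), which lies within the scatter. Extending the ester by a methyl gives a 1.3-fold lower number from compound 1 to compound 4 (0.11 log units; within the scatter), also within the scatter, so neither edit separates these compounds.

Nothing available explains the size of the large step. From the compounds shown here alone, it remains open how an amine or a carboxylic acid on the ring of the benzoyl group, or a longer chain on the ester, would shift the number.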